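Pentyl in place of acetyl on an oxygen

The source may report more compounds than this note shows. Statements on the series, on what has been measured and on what is new or still open speak of the compounds shown alone.

In a functional assay on A549 cells (Homo sapiens) for cytotoxicity, with a stated time of 48 h (on this read-out lower numbers stand for stronger inhibition and higher numbers for weaker inhibition), compound 1 `Cc1ccc2c(=O)cc(/C=C/[S+](C)[O-])oc2c1` gives 2000 nM and compound 2 `CCOc1ccc2oc(/C=C/[S+](C)[O-])cc(=O)c2c1` gives 1500 nM while compound 3 `CC(=O)Oc1ccc2oc(/C=C/[S+](C)[O-])cc(=O)c2c1` gives 4100 nM as the highest of the three numbers. Compound 4 `CCCCCOc1ccc2oc(/C=C/[S+](C)[O-])cc(=O)c2c1` has not yet been measured. It differs from compound 3 by pentyl in place of acetyl on an oxygen on an aromatic ring and so carries a carbon chain there, as compound 2 does, only a longer one. For the measured compounds named here, the one measured step at that oxygen is a 2.7-fold higher number from compound 2 to compound 3 (0.44 log units; beyond the scatter) and it is modest yet beyond the scatter. Nothing measured shows what a longer chain does. Reading that step backwards, a modest move to a lower number is expected, estimated as a 2.3-fold lower number from compound 3 to compound 4 (0.36 log units; beyond the scatter) in this assay for this change. For compound 4 the estimated value is 1800 nM with an expected range from 600 nM to 4500 nM as the likely span.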

Compound 4, half-maximal inhibitory concentration: 1600 nM
Beside the measured number, compound 4's estimate is 1.1-fold (0.05 log units) above it; measured number inside the range.
By their numbers in this assay, from the lowest: compounds 2, 4 and 1 (each within the scatter of the next); then compound 3.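

Pentyl in place of acetyl on the oxygen gives a 2.6-fold lower number from compound 3 to compound 4 (0.41 log units; beyond the scatter) in this assay and so shows that a second carbon chain at this oxygen, not only ethyl, avoids the higher number seen with acetyl. Going from ethyl to the longer pentyl chain gives a 1.1-fold higher number from compound 2 to compound 4 (0.03 log units; within the scatter) and so shows no change that can be told from scatter. No evidence here explains why acetyl stands apart from these two chains.

Going by these compounds, whether a still longer chain would keep this level remains open, as does the effect of an amine or a carboxylic acid at this oxygen.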